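Half-life notes: from piperidine to piperazine

The source may report more compounds than this note shows. Statements on the series, on what has been measured and on what is new or still open speak of the compounds shown alone.

Measured in an ADME assay on a cell-free system (plasma, Mus musculus) for metabolic stability, read by LC-MS, tested at 2 uM; a higher number here means that the compound lasts longer, a lower number that the compound disappears faster:
- compound 1 `CC(C)CNC(=O)n1c(=O)oc2c(C3CCN(C)CC3)cccc21`: 0.667 h
- compound 2 `CN1CCN(c2ccc3c(c2)oc(=O)n3C(=O)NCCCCc2ccccc2)C(=O)C1`: 0.333 h
- compound 3 `CC(C)CN1CCC(c2ccc3c(c2)oc(=O)n3C(=O)NCCCCc2ccccc2)CC1`: 1 h

Compound 3 stands at 1 h, and compound 1, at 0.667 h, lies within the scatter of it. Compound 2 lies further off, at 0.333 h, beyond the scatter of compound 3.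

The next structure is compound 4 `CCN1CCN(c2ccc3c(c2)oc(=O)n3C(=O)NCCCCc2ccccc2)CC1`, not yet measured in this assay. It carries 4-ethylpiperazin-1-yl in place of 1-isobutylpiperidin-4-yl on an aromatic carbon.

For the measured compounds named here, one measured step bears on this change: a 3.0-fold higher number from compound 2 to compound 3 (0.48 log units; beyond the scatter). That step is modest, lies beyond the scatter and falls on the same aromatic carbon, with 1-isobutylpiperidin-4-yl in place of 4-methyl-2-oxopiperazin-1-yl. Going by the values given here, the entering group of compound 4 resembles by name the 4-methyl-2-oxopiperazin-1-yl group of compound 2, but it is not the same group, and no measured compound carries it. Only part of the measured step is therefore likely to carry over, and a single step sets no firm pattern.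

The expected step is a small one downward, a 1.4-fold lower number from compound 3 to compound 4 (0.15 log units; within the scatter), and it is estimated to stay within the scatter. For compound 4 the estimated value is 0.7 h, with an expected range of 0.33 h to 1.4 h.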

Compound 4, half-life: < 0.0834 h
Compound 4 gave a limit, no number; the forecaster's own chance of this, stated with the estimate: 3%; at least 8.3-fold (0.92 log units) between middle value and limit.
By their numbers in this assay, from the lowest: compounds 2, 1 and 3 (each within the scatter of the next, the first and the last beyond it). At a limit, below all of these: compound 4.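

In this assay compound 4 gives a limit and no number: the limit of < 0.0834 h in this assay, at which 1 of the 4 values shown sits. For the compounds shown here, on this aromatic carbon, 4-ethylpiperazin-1-yl in place of 1-isobutylpiperidin-4-yl gives an at least 11-fold lower number from compound 3 to compound 4 (1.07 log units; beyond the scatter), a larger step than the earlier 3.0-fold higher number from compound 2 to compound 3 (0.48 log units; beyond the scatter), so the group at this position can shift the half-life much further than the earlier compounds showed. The two groups with a piperazine name also stand apart, with 4-ethylpiperazin-1-yl in place of 4-methyl-2-oxopiperazin-1-yl giving an at least 3.9-fold lower number from compound 2 to compound 4 (0.60 log units; beyond the scatter), so in this small set a shared name does not mean a shared half-life.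

The step from compound 3 to compound 4 changes both the ring, which gains a second hetero atom, and the chain on it, from isobutyl to ethyl, so the compounds shown do not tell which of the two carries the drop. Going by these compounds, a 1-ethylpiperidin-4-yl or a 4-isobutylpiperazin-1-yl group on the same aromatic carbon would separate the two, and the size of the drop remains open while compound 4 stands at a limit.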